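A few compounds are considered here, and "the series" means these few. Any claim that something is new, unique, unknown or untested is made for them only; others in the source may bear on it.

Compound 2 `CC(C)CCn1c(CN2CCN(C(=O)C3CC3)CC2)nc2ccccc21` gives 70% in an assay on isolated protein for inhibition of aldehyde dehydrogenase 1A1 (Homo sapiens), read by spectrophotometry, tested at 10 uM (a lower number here means less inhibition, a higher number more inhibition at the concentration tested (going by the name of the read-out)), the highest of the three numbers measured. Compound 1 `O=C(C1CC1)N1CCN(Cc2nc3ccccc3n2Cc2ccccc2C(F)(F)F)CC1` gives 56.3% and compound 3 `O=C(C1CC1)N1CCN(Cc2nc3ccccc3n2Cc2ccc(Cl)cc2)CC1` gives 56.6%. The measured steps are a number 13.7 percentage points higher from compound 1 to compound 2 (beyond the scatter) and a number 13.4 percentage points lower from compound 2 to compound 3 (beyond the scatter), while a number 0.3 percentage points higher from compound 1 to compound 3 (within the scatter). Compound 4 `CC(C)CCn1c(CN2CCN(C(=O)c3ccco3)CC2)nc2ccccc21` differs from compound 2 in one place: furan-2-yl in place of cyclopropyl on a carbonyl carbon. Within the data shown here, none of the measured steps touches the carbonyl carbon; all three vary the group on the saturated chain carbon bound to the aromatic nitrogen, so nothing measured bears directly on this change. The expected step is therefore a number 5 percentage points lower from compound 2 to compound 4 (within the scatter), nothing beyond the scatter. Compound 4 is expected to give 65%, between 50% and 80%, in this assay.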

Compound 4, a percentage reported as inhibition, at one concentration (the size of the read-out at that concentration, not a potency): 42.1%
Compound 4: middle estimate off by 22.9 percentage points, on the high side; measured number below the stated range.
By their numbers in this assay, from the lowest: compound 4; then compounds 1 and 3 (each within the scatter of the next); then compound 2.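

In this assay, the carbonyl carbon proves to be a position that responds to its group: with furan-2-yl in place of cyclopropyl there is a number 27.9 percentage points lower from compound 2 to compound 4 (beyond the scatter) on the isobutyl-type chain of compound 2. Among these compounds, the earlier compounds varied only the group on the saturated chain carbon, so this is the first sign that the cyclopropylcarbonyl part is not indifferent. Nothing available explains the change.

A phenyl or a tetrahydrofuran-2-yl group on the same carbonyl carbon would show whether the aromatic ring or the ring oxygen goes with the lower number. On these data alone, whether the step holds with 4-chlorophenyl on the chain carbon remains open.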